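This account rests on a few compounds, and the source may have more. Where it says the series, first, only, none or still open, it means among the compounds named here.

Measured in an ADME assay on NHDF cells (Homo sapiens) for antiproliferative activity, with a stated time of 72 h; a lower number here means a stronger inhibitor, a higher number a weaker inhibitor:
- Compound 1 `CC(=O)Oc1cccc(/C=C/c2nc3ccccc3c(=O)[nH]2)c1` gives > 25000 nM (a limit)
- Compound 2 `COc1ccccc1/C=C/c1nc(Nc2cccc(O)c2)c2ccccc2n1` gives 17500 nM
- Compound 3 `COc1ccc(/C=C/c2nc(Nc3cccc(O)c3)c3ccccc3n2)cc1` gives > 25000 nM (a limit)

Compound 3 has no exact number, only a limit. It sits at the limit of > 25000 nM in this assay, at which 2 of the 3 values shown sit, and so marks the weak end of what this test can report. Compound 4 `O=[N+]([O-])c1cccc(/C=C/c2nc(Nc3cccc(O)c3)c3ccccc3n2)c1` differs from compound 3 in one place, with 3-nitrophenyl in place of 4-methoxyphenyl on a double-bonded chain carbon bound to a double-bonded chain carbon. For the measured compounds named here, the only measured step at this place is an at least 1.4-fold higher number from compound 2 to compound 3 (0.15 log units; that floor lies within the scatter) and it moves a methoxy group rather than bringing in a nitro group. It therefore gives only weak guidance. Going by the values given here, with compound 2 at 17500 nM as the one exact value nearby, no step beyond the scatter is expected in this assay for this change. The expected size is a number no higher from compound 3 to compound 4 (the limit leaves the size open) and this is only an estimate. Compound 4 is expected at 25000 nM within an estimated range of 12000 nM to 50000 nM and may well return only a limit.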

Compound 4, half-maximal inhibitory concentration: 11200 nM
Compound 4: middle estimate off by 2.2-fold (0.35 log units), on the high side, and the stated range ends above it.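

In this assay, for the compounds shown here, 3-nitrophenyl in place of 4-methoxyphenyl on a double-bonded chain carbon gives the only step at this place that lies beyond the scatter: an at least 2.2-fold lower number from compound 3 to compound 4 (0.34 log units; beyond the scatter). That size is only a floor, because compound 3 has a limit and not an exact number: the limit of > 25000 nM in this assay, at which 2 of the 4 values shown sit.

The nitro compound does not stand apart from both methoxy compounds, however: a 1.6-fold lower number from compound 2 to compound 4 (0.19 log units; within the scatter), so 3-nitrophenyl and 2-methoxyphenyl cannot be told apart in this test.

The compounds shown leave open whether the nitro group itself or its place on the phenyl ring matters more, as neither 4-nitrophenyl nor 3-methoxyphenyl is among them. On these data alone, how an amine or a carboxylic acid on that phenyl ring would read also remains open.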